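Aryl triazole esters: compound 3 to compound 4

The source may hold more compounds than are shown below. What is called first, only, known or untested is meant among the compounds shown, and "the series" means these compounds.

Measured in an ADME assay on L132 cells (Homo sapiens) for cytotoxicity, read by MTT assay, with a stated time of 48 h; on this read-out lower numbers stand for stronger inhibition and higher numbers for weaker inhibition:
- compound 1 `C/C(=C\CC/C(C)=C/CC[C@@H]1[C@@]2(C)CCC(=O)C(C)(C)[C@H]2CC[C@@]1(C)O)CC/C=C(\C)C(=O)OCc1cn(-c2ccccc2Br)nn1`: > 150000 nM, a limit
- compound 2 `COc1ccc(-n2cc(COC(=O)/C(C)=C/CC/C(C)=C/CC/C(C)=C/CC[C@@H]3[C@@]4(C)CCC(=O)C(C)(C)[C@H]4CC[C@@]3(C)O)nn2)cc1`: > 150000 nM, a limit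
- compound 3 `C/C(=C\CC/C(C)=C/CC[C@@H]1[C@@]2(C)CCC(=O)C(C)(C)[C@H]2CC[C@@]1(C)O)CC/C=C(\C)C(=O)OCc1cn(-c2ccccc2Cl)nn1`: > 150000 nM, a limit
- compound 4 `C/C(=C\CC/C(C)=C/CC[C@@H]1[C@@]2(C)CCC(=O)C(C)(C)[C@H]2CC[C@@]1(C)O)CC/C=C(\C)C(=O)OCc1cn(-c2cccc(O)c2)nn1`: not yet measured

Compound 3 has no number, only the limit > 150000 nM. Within the data shown here, the series so far sits at the limit of > 150000 nM in this assay, at which 3 of the 3 values shown sit.

The next change is 3-hydroxyphenyl in place of 2-chlorophenyl on an aromatic nitrogen. Among the measured compounds shown here, no measured compound carries this group, so the comparison rests on other changes at the same place. Those steps are a step that the two limits leave unreadable from compound 2 to compound 3 and a step that the two limits leave unreadable from compound 1 to compound 2. The halogen change is a step that the two limits leave unreadable from compound 1 to compound 3. None of them has a readable size, so they give no direction and no measured basis for expecting a real shift in this assay. Compound 4 is therefore expected to stay in the same region as its three relatives, most likely reported as a limit again. The expected change is a step that the limit leaves unreadable from compound 3 to compound 4. For compound 4 the estimated value is 180000 nM, with an expected range of 90000 nM to 320000 nM.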

Compound 4, half-maximal inhibitory concentration: 146000 nM
Estimate against measurement, compound 4: 1.2-fold (0.09 log units) above; the measured number falls inside the stated range.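

In this assay, compound 4, carrying 3-hydroxyphenyl on the aromatic nitrogen, is the only compound shown with a number rather than a limit. Its steps are an at least 1.0-fold lower number from compound 3 to compound 4 (0.01 log units; that floor lies within the scatter), an at least 1.0-fold lower number from compound 2 to compound 4 (0.01 log units; that floor lies within the scatter) and an at least 1.0-fold lower number from compound 1 to compound 4 (0.01 log units; that floor lies within the scatter), so each floor stays within the scatter and no real shift at this position is established. The steps among compound 1, compound 2 and compound 3 cannot be read, and those three remain bounded from one side only: the limit of > 150000 nM in this assay, at which 3 of the 4 values shown sit.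

From the compounds shown here alone, whether 3-hydroxyphenyl truly differs from the other aryl groups remains open, as the true values behind the limits are unknown. Also open, going by these compounds, is how this assay would respond to an aryl group bearing an amine or a carboxylic acid at this position.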